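Trifluoromethyl to methoxy in the ethylamino series

This account rests on a few compounds, and the source may have more. Where it says the series, first, only, none or still open, it means among the compounds named here.

- compound 1 `CCNc1cc(-c2ccc(NC(=O)Nc3ccc(C)cc3)cc2C(F)(F)F)ccn1`: 9470 nM
- compound 2 `CCNc1cc(-c2ccc(NC(=O)Nc3ccc(C(F)(F)F)cc3)cc2C(F)(F)F)ccn1`: 2390 nM

Among the compounds with values here, in a functional assay on MCF7 cells (Homo sapiens) for cytotoxicity, read by MTT assay, with a stated time of 24 h (on this read-out higher numbers stand for weaker inhibition and lower numbers for stronger inhibition), compound 2 gives 2390 nM, the lower of the two numbers so far, and it sits clearly apart from compound 1.

The next structure is compound 3 `CCNc1cc(-c2ccc(NC(=O)Nc3ccc(C(F)(F)F)cc3)cc2OC)ccn1`. The change is methoxy in place of trifluoromethyl on an aromatic carbon, ortho to a 2-(ethylamino)pyridin-4-yl group.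

Within the data shown here, only one measured step is available, a 4.0-fold lower number from compound 1 to compound 2 (0.60 log units; beyond the scatter). It is modest and beyond the scatter. Among the measured compounds shown here, it also swaps trifluoromethyl for methyl on a different aromatic carbon, so it gives a rough scale for a single-group change but no direct precedent. For the measured compounds named here, no measured compound carries methoxy, and no measured step changes the group at this place.

Going by the number for compound 2 and the direction of the one step in which trifluoromethyl entered, a modest move towards a higher number is the tentative expectation. The expected step is a 1.9-fold higher number from compound 2 to compound 3 (0.27 log units; within the scatter). For compound 3 the estimated value is 4500 nM, with an expected range from 1700 nM to 12000 nM.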

Compound 3, half-maximal inhibitory concentration: 19500 nM
Beside the measured number, compound 3's estimate is 4.3-fold (0.64 log units) below it, outside the stated range (above it).
By their numbers in this assay, from the lowest: compound 2; then compound 1; then compound 3.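

In this assay, the aromatic carbon ortho to a 2-(ethylamino)pyridin-4-yl group is now shown to respond to a single-group change: methoxy in place of trifluoromethyl gives an 8.2-fold higher number from compound 2 to compound 3 (0.91 log units; beyond the scatter). The lower number goes with trifluoromethyl at this place, as it also does at the other aromatic carbon in the step of a 4.0-fold lower number from compound 1 to compound 2 (0.60 log units; beyond the scatter), although that step replaces methyl rather than methoxy, so the two changes are not the same. Nothing available bears on why methoxy gives the higher number at this place.

With only trifluoromethyl and methoxy at this place, the compounds shown leave open whether the higher number is particular to methoxy or follows any replacement of trifluoromethyl, and a chlorine atom or an amine at the same carbon would help separate these two readings. Also open, as far as these compounds go, is whether the step from trifluoromethyl to methoxy keeps its direction and size when methyl, as in compound 1, stands at the other aromatic carbon.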